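The source may report more compounds than this note shows. Statements on the series, on what has been measured and on what is new or still open speak of the compounds shown alone.

Measured so far in a functional assay on Ehrlich cells (Mus musculus) for antiproliferative activity, read by trypan blue exclusion, with a stated time of 2 h, tested at 100 ug/mL; on this read-out higher numbers stand for a stronger effect at the one concentration tested and lower numbers for a weaker effect:
compound 1 `N#CC1=C(N)N(c2ccc(S(N)(=O)=O)cc2)C2=C(C(=O)CCC2)C1c1ccc([N+](=O)[O-])cc1` gives 100%
compound 2 `N#CC1=C(N)N(c2ccc(S(N)(=O)=O)cc2)C2=C(C(=O)CCC2)C1c1ccc(Cl)cc1Cl` gives 95%

For the measured compounds named here, compound 2 stands beside compound 1 as the only other number on this read-out; the two values lie within the scatter of each other, so no order between them can be claimed. Going by the values given here, the one measured step, a number 5 percentage points lower from compound 1 to compound 2 (within the scatter), swaps one aryl group for another on the saturated ring carbon of the shared core and leaves the read-out essentially unchanged.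

Compound 3 `N#CC1=C(N)N(c2ccc(S(N)(=O)=O)cc2)C2=C(C(=O)CCC2)C1c1c(O)ccc2ccccc12` is the next member. The change from compound 2 is 2-hydroxynaphthalen-1-yl in place of 2,4-dichlorophenyl on a saturated ring carbon. Among the compounds with values here, it is again an exchange of the aryl group on the same saturated ring carbon, so the only step that bears on it is the one from compound 1 to compound 2, which was within the scatter. On that basis the expected step is a number 5 percentage points lower from compound 2 to compound 3 (within the scatter), that is, none beyond the scatter in either direction; the read-out of compound 2 already sits near the top of the scale, which leaves more room downward than upward. The value for compound 3 is therefore estimated at 90%, in the range 70% to 100%.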

Compound 3, a percentage reported as activity, at one concentration (the size of the read-out at that concentration, not a potency): 15%
Compound 3: middle estimate off by 75 percentage points, on the high side; the measured number lies below the stated range.
By their numbers in this assay, from the lowest: compound 3; then compounds 2 and 1 (each within the scatter of the next).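

In this assay, the aryl group on the saturated ring carbon proves able to change the read-out strongly: the exchange for 2-hydroxynaphthalen-1-yl gives a number 80 percentage points lower from compound 2 to compound 3 (beyond the scatter) and a number 85 percentage points lower from compound 1 to compound 3 (beyond the scatter), whereas the earlier exchange gave only a number 5 percentage points lower from compound 1 to compound 2 (within the scatter). So 4-nitrophenyl and 2,4-dichlorophenyl cannot be told apart here, and the insensitivity suggested by those two compounds does not extend to 2-hydroxynaphthalen-1-yl. This exchange alters several things at once, bringing in 2 six-membered aromatic rings of carbon only, 1 hydrogen-bond donor and 1 hydrogen-bond acceptor, and no measurement is at hand that would explain the fall.

From the compounds shown here alone, it remains open whether the fall goes with the hydroxy group or with the second aromatic ring, a question that a plain naphthalen-1-yl group and a 2-hydroxyphenyl group on the same carbon would separate. Also open, going by these compounds, is what a methoxy group in place of the hydroxy group would give, and whether the 4-sulfamoylphenyl group, the same in all three compounds, could give way to a 4-carboxyphenyl group with the read-out kept.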